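This account rests on a few compounds, and the source may have more. Where it says the series, first, only, none or still open, it means among the compounds named here.

Compound 2 `Cn1cccc1-c1cc(-c2cccs2)[nH]c(=O)c1C#N` gives > 100000 nM in a functional assay on SF-268 cells (Homo sapiens) for inhibition, read by sulforhodamine B assay, with a stated time of 48 h (on this read-out lower numbers stand for stronger inhibition of growth and higher numbers for weaker inhibition of growth), which is a limit of the assay and not a number. Compound 1 `COc1ccc(-c2cc(-c3cccn3C)c(C#N)c(=O)[nH]2)cc1OC` gives > 100000 nM in this assay, likewise a limit. Within the data shown here, both values sit at the limit of > 100000 nM in this assay, at which 2 of the 2 values shown sit, so no measured step exists. Compound 3 `Cn1cccc1-c1cc(-c2ccccc2)[nH]c(=O)c1C#N` differs from compound 2 by phenyl in place of thiophen-2-yl on an aromatic carbon. The step from compound 2 to compound 3 is expected to be none beyond the scatter, most likely another limit. Compound 3 is estimated at 100000 nM, range 30000 nM to 300000 nM. The expected step is a number no higher from compound 2 to compound 3 (the limit leaves the size open).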

Compound 3, concentration for 50% growth inhibition: > 100000 nM
Compound 3: a limit, no number (the forecaster's own chance of this, stated with the estimate: 80%); the middle value lies on the limit itself.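

Among these compounds, compound 3 gives > 100000 nM, a limit and not a number, so no step from compound 2 to compound 3 can be read. The compounds shown leave open which change to the shared core, if any, would give a readable growth-inhibition value: the limit of > 100000 nM in this assay, at which 3 of the 3 values shown sit.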